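Changing the phenoxy group in an antiproliferative series

The source may report more compounds than this note shows. Statements on the series, on what has been measured and on what is new or still open speak of the compounds shown alone.

Compound 1 `Cc1ccc(Oc2c(/C=N\CCCCCOc3cc4oc(=O)cc(C)c4cc3Cl)c(C)nn2C)cc1`: 7970 nM
Compound 2 `Cc1nn(C)c(Oc2ccc(F)c(F)c2)c1/C=N\CCCCCCOc1cc2oc(=O)cc(C)c2cc1Cl`: > 25000 nM

In a functional assay on U-87MG ATCC cells for antiproliferative activity against U-87 MG (Homo sapiens), read by MTT assay, with a stated time of 72 h (a lower number here means a stronger inhibitor, a higher number a weaker inhibitor), compound 1 gives 7970 nM. Compound 2 gives only a limit in this assay, > 25000 nM, so its true value is not known. Its result sits at the limit of > 25000 nM in this assay, at which 1 of the 2 values shown sits. Within the data shown here, no step between measured compounds is counted here. Compound 3 `Cc1nn(C)c(Oc2cccc(C(F)(F)F)c2)c1/C=N\CCCCCCOc1cc2oc(=O)cc(C)c2cc1Cl` differs from compound 2 by 3-(trifluoromethyl)phenyl in place of 3,4-difluorophenyl on an oxygen on an aromatic ring. Because compound 2 stands at the limit of > 25000 nM in this assay, at which 1 of the 2 values shown sits, the step to compound 3 cannot be sized from the data, and a step of an at least 1.2-fold lower number from compound 2 to compound 3 (0.09 log units; that floor lies within the scatter) is expected, within scatter. Compound 3 is estimated at 20000 nM, in a range from 8000 nM to 50000 nM.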

Compound 3, half-maximal inhibitory concentration: 23400 nM
Compound 3: the middle estimate sits 1.2-fold (0.07 log units) below what was measured; the range from low to high includes it.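

Compound 3 gives a readable number in this assay, 23400 nM, so 3-(trifluoromethyl)phenyl on this oxygen keeps the result within the range of the assay. The change from 3,4-difluorophenyl can be stated only as an at least 1.0-fold lower number from compound 2 to compound 3 (0.02 log units; that floor lies within the scatter). Its true size stays unknown, and the value of compound 2 is a limit: the limit of > 25000 nM in this assay, at which 1 of the 3 values shown sits.

From the compounds shown here alone, it remains open whether an amine or a carboxylic acid on this phenyl ring would move the number beyond the scatter. Compound 1 differs from compound 2 and compound 3 in more than one place, so the phenoxy group's own contribution there stays unresolved.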